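The source may hold more compounds than are shown below. What is called first, only, known or untested is meant among the compounds shown, and "the series" means these compounds.

Compound 1 `CCN(CC)CCCn1c(=O)c(=Cc2ccc(O)cc2)s/c1=C1\C(=O)Nc2ccc(C)cc21` is the anchor of this small set. In a functional assay on NCI-H460 cells (Homo sapiens) for inhibition, read by MTT assay, with a stated time of 72 h (on this read-out higher numbers stand for weaker inhibition and lower numbers for stronger inhibition), compound 1 gives 260 nM, the lowest of the three numbers recorded so far. Compound 2 `COc1cc(C=c2s/c(=C3\C(=O)Nc4ccc(F)cc43)n(CCN(C)C)c2=O)cc(OC)c1OC` gives in this assay 1700 nM, a weaker result that lies beyond the scatter relative to compound 1, and compound 3 `CCN(CC)CCCn1c(=O)c(=Cc2ccc(F)cc2F)s/c1=C1\C(=O)Nc2cc(F)ccc21` gives in this assay 2330 nM, weaker again. These compounds differ from compound 1 in more than one place at once. Nothing can be read from them about any single change; only the values themselves are known.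

Compound 4 `CCN(CC)CCCn1c(=O)c(=Cc2ccccc2O)s/c1=C1\C(=O)Nc2ccc(C)cc21` has not yet been tested. It contains exactly the same atoms as compound 1, joined differently: 2-hydroxyphenyl in place of 4-hydroxyphenyl on a double-bonded chain carbon bound to an aromatic carbon. Within the data shown here, no measured pair in this set differs by this change alone, so the size of the step has to be judged without a precedent. For compound 4 the expected step is a 1.9-fold higher number from compound 1 to compound 4 (0.28 log units; within the scatter) in this assay, a modest move toward weaker inhibition that may or may not exceed the scatter. Compound 4 is therefore estimated at 500 nM in this assay, with a likely range from 150 nM to 1800 nM.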

Compound 4, half-maximal inhibitory concentration: 11300 nM
Beside the measured number, compound 4's estimate is 23-fold (1.35 log units) below it, outside the stated range (above it).
By their numbers in this assay, from the lowest: compound 1; then compounds 2 and 3 (each within the scatter of the next); then compound 4.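

Among these compounds, the exchange of 4-hydroxyphenyl for 2-hydroxyphenyl, on a double-bonded chain carbon bound to an aromatic carbon, is the first single change that can be read in this set, and in this assay it amounts to a 43-fold higher number from compound 1 to compound 4 (1.64 log units; beyond the scatter). Among the compounds shown here, the two groups have the same heavy atoms and the same counts of donors and acceptors, so this large step shows that the number at this position depends on where the hydroxyl stands on the ring and not only on which atoms are present, something the earlier compounds, each differing in more than one place, could not show. Nothing available here explains why the rearrangement has a step of this size.

From the compounds shown here alone, it remains open how an unsubstituted phenyl, or a phenyl carrying an amine or a carboxylic acid, would compare in this place with 4-hydroxyphenyl and 2-hydroxyphenyl. Going by these compounds, it is also open whether the same exchange would give a step of similar size on the core of compound 2 or compound 3, whose other groups differ.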